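The source may report more compounds than this note shows. Statements on the series, on what has been measured and on what is new or still open speak of the compounds shown alone.

Values measured so far in a functional assay on HeLa cells (Homo sapiens) for antiproliferative activity, read by MTT assay, with a stated time of 72 h; a lower number here means a stronger inhibitor, a higher number a weaker inhibitor
Compound 1 `CCn1cc(C(=O)O)c(=O)c2cc(F)c(N3CCN(C(=N)NS(=O)(=O)c4cccc(Cl)c4)CC3)cc21` gives 32 nM
Compound 2 `N=C(NS(=O)(=O)c1cccc(Cl)c1)N1CCN(c2cc3c(cc2F)c(=O)c(C(=O)O)cn3C2CC2)CC1` gives 32 nM
Compound 3 `N=C(NS(=O)(=O)c1ccc(C(F)(F)F)cc1)N1CCN(c2cc3c(cc2F)c(=O)c(C(=O)O)cn3C2CC2)CC1` gives 32 nM

Compound 1 stands level with compound 2 and compound 3 at the digits shown. Compound 4 `CCn1cc(C(=O)O)c(=O)c2cc(F)c(N3CCN(C(=N)NS(=O)(=O)c4ccc(Cl)cc4)CC3)cc21` is still unmeasured. Its structure differs from compound 1 in one place: 4-chlorophenyl in place of 3-chlorophenyl on a sulfonyl sulfur, which in words is 4-chlorophenyl in place of 3-chlorophenyl on a sulfonyl sulfur. The closest evidence is no change at the digits printed from compound 2 to compound 3 (within the scatter), which also replaces 3-chlorophenyl on a sulfonyl sulfur. A change elsewhere, cyclopropyl in place of ethyl on an aromatic nitrogen, gave no change at the digits printed from compound 1 to compound 2 (within the scatter). Neither step leaves the scatter, so no step beyond it is expected in this assay. The expected step is no change at the digits printed from compound 1 to compound 4 (within the scatter). Compound 4 is estimated at 32 nM, with an expected range of 14 nM to 80 nM.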

Compound 4, half-maximal inhibitory concentration: 32 nM
Beside the measured number, compound 4's estimate shows no gap at the digits printed; the measured number falls inside the stated range.
By their numbers in this assay, from the lowest: compounds 1, 2, 3 and 4 (each within the scatter of the next).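

In this assay the swap of 3-chlorophenyl for 4-chlorophenyl on the sulfonyl sulfur gives no change at the digits printed from compound 1 to compound 4 (within the scatter). Among these compounds, the earlier change at this sulfur replaced the chlorine with trifluoromethyl as well as changing where the ring carried its group, whereas here the atoms stay the same and only their connection differs, so moving the chlorine alone is seen for the first time. Nothing available explains this result. Still open, as far as these compounds go, is whether an unsubstituted phenyl, a phenyl carrying an amine or a carboxylic acid, or a longer alkyl chain on this sulfur would keep the value unchanged.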